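The source may hold more compounds than are shown below. What is called first, only, known or untested is meant among the compounds shown, and "the series" means these compounds.

Measured so far:
Compound 1, `CCN(CC)c1ccc2cc(C(=O)c3ccc(N4CCN(C(=O)CN5CCN(S(=O)(=O)C6CC6)CC5)CC4)cc3)oc2c1`, in a functional assay on HCT-116 cells (Homo sapiens) for cytotoxicity, read by MTT assay, with a stated time of 48 h (on this read-out higher numbers stand for weaker inhibition and lower numbers for stronger inhibition), gives > 40000 nM; this is a limit of the assay and not a number.
Compound 2, `CCN(CC)c1ccc2cc(C(=O)c3ccc(N4CCN(C(=O)CN5CCN(S(=O)(=O)c6ccc(C#N)cc6)CC5)CC4)cc3)oc2c1`, gives 36400 nM.
Compound 3, `CCN(CC)c1ccc2cc(C(=O)c3ccc(N4CCN(C(=O)CN5CCN(Cc6ccc(F)c(F)c6)CC5)CC4)cc3)oc2c1`, gives 26300 nM.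

Among the measured compounds shown here, compound 2 and compound 3 are the only two with numbers, and the step between them, a 1.4-fold lower number from compound 2 to compound 3 (0.14 log units; within the scatter), keeps both on the same footing, so compound 2 stands among weak inhibitors with no clear separation from compound 3. Compound 1 sits at a limit (the limit of > 40000 nM in this assay, at which 1 of the 3 values shown sits), and the steps of an at least 1.0-fold lower number from compound 1 to compound 2 (0.04 log units; that floor lies within the scatter) and an at least 1.5-fold lower number from compound 1 to compound 3 (0.18 log units; that floor lies within the scatter) are only floors.

Compound 4, `CCOC(=O)CN1CCN(CC(=O)N2CCN(c3ccc(C(=O)c4cc5ccc(N(CC)CC)cc5o4)cc3)CC2)CC1`, differs from compound 2 in this way: (ethoxycarbonyl)methyl in place of (4-cyanophenyl)sulfonyl on an amine nitrogen in a ring. The measured steps all change the group on the same ring nitrogen, and none of them moved the read-out beyond the scatter. The change to compound 4 again swaps that group, so no step beyond the scatter is expected in this assay.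

Compound 4 is therefore expected to give 35000 nM, within 15000 nM to 80000 nM. The expected step is a 1.0-fold lower number from compound 2 to compound 4 (0.02 log units; within the scatter).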

Compound 4, half-maximal inhibitory concentration: > 40000 nM
Compound 4: a limit, no number (the forecaster's own chance of this, stated with the estimate: 30%); middle value at least 1.1-fold (0.05 log units) from the limit.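

In this assay compound 4 gives > 40000 nM, which is a limit of the assay and not a number. Swapping the ring-bearing groups on this ring nitrogen for (ethoxycarbonyl)methyl, which has no ring, gives only floors, an at least 1.0-fold higher number from compound 2 to compound 4 (0.04 log units; that floor lies within the scatter) and an at least 1.5-fold higher number from compound 3 to compound 4 (0.18 log units; that floor lies within the scatter), so this change is not separated from either group. The step linking compound 1 and compound 4 cannot be read, and the values for this set of groups now gather at one limit: the limit of > 40000 nM in this assay, at which 2 of the 4 values shown sit.

On these data alone, whether a carboxylic acid in place of the ethyl ester, or an amine or a longer chain on this ring nitrogen, would give a number clearly lower than these stays open. So does the effect of any change elsewhere, in the shared core.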